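Replacing 6-methoxypyridin-3-yl with 1-benzothiophen-5-yl on a shared core

A few compounds are considered here, and "the series" means these few. Any claim that something is new, unique, unknown or untested is made for them only; others in the source may bear on it.

In an ADME assay (liver) for metabolic stability, with Liver microsome (Rattus norvegicus) as the target, using microsomes and NADPH, with a stated time of 30 min, tested at 1 uM (a higher number here means faster removal of the compound, a lower number slower removal), compound 1 `CC(C)n1cc(-c2cc(C(O)(C(F)(F)F)C(F)(F)F)cnc2N2CCN(S(=O)(=O)c3ccc(N)nc3)CC2)cn1` gives 198 mL.min-1.g-1. Compound 2 `COc1ccc(-c2cc(C(O)(C(F)(F)F)C(F)(F)F)cnc2N2CCN(S(=O)(=O)c3ccc(N)nc3)CC2)cn1` gives 265 mL.min-1.g-1. Only these two numbers exist so far, and they lie within the scatter of each other, so compound 1 is the nearest neighbour of compound 2 and no order can be read between them.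

Compound 3 `Nc1ccc(S(=O)(=O)N2CCN(c3ncc(C(O)(C(F)(F)F)C(F)(F)F)cc3-c3ccc4sccc4c3)CC2)cn1` has not yet been measured. It differs from compound 2 in one place, where 1-benzothiophen-5-yl stands in place of 6-methoxypyridin-3-yl on an aromatic carbon: 1-benzothiophen-5-yl in place of 6-methoxypyridin-3-yl on an aromatic carbon.

For the measured compounds named here, one measured step bears on this, since it concerns the same place: a 1.3-fold higher number from compound 1 to compound 2 (0.13 log units; within the scatter). That step stays within the scatter. It is a single step, however, and neither measured compound carries 1-benzothiophen-5-yl, so the evidence is thin and the range must stay wide. In this assay, no move beyond the scatter is expected, and the estimated step is a 1.1-fold higher number from compound 2 to compound 3 (0.02 log units; within the scatter). For compound 3, the intrinsic clearance is estimated at 280 mL.min-1.g-1, with an expected range from 130 mL.min-1.g-1 to 600 mL.min-1.g-1.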

Compound 3, intrinsic clearance in microsomes: 487 mL.min-1.g-1
Beside the measured number, compound 3's estimate is 1.7-fold (0.24 log units) below it; the measured number falls inside the stated range.
By their numbers in this assay, from the lowest: compounds 1, 2 and 3 (each within the scatter of the next, the first and the last beyond it).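

In this assay this position now gives its first step beyond the scatter, a 2.5-fold higher number from compound 1 to compound 3 (0.39 log units; beyond the scatter) when 1-benzothiophen-5-yl stands in place of 1-isopropyl-1H-pyrazol-4-yl on an aromatic carbon, which shows that the group here can shift the intrinsic clearance, if only modestly. The other new step, a 1.8-fold higher number from compound 2 to compound 3 (0.26 log units; within the scatter) with 1-benzothiophen-5-yl in place of 6-methoxypyridin-3-yl, stays within the scatter, so compound 2 and compound 3 cannot be told apart, and only compound 1 and compound 3 stand clearly apart. No measurement at hand explains why the clearance differs between these groups.

Going by these compounds, all three groups at this position are aromatic rings, so what an amine, a carboxylic acid or a longer alkyl chain would do at the same carbon stays open. Also open, on these data alone, is whether 1-benzothiophen-5-yl would give a similar step on a different core, as every step here sits on one shared core.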